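The compounds below may be only part of what the source reports. "The series", "measured", "known", "first", "only" and "open" are said of these compounds alone.

Of the compounds shown here, three built on one shared core have been measured in an assay on COS-7 cells for inhibition of patatin-like phospholipase domain-containing protein 2 (Mus musculus); on this read-out lower numbers stand for stronger inhibition and higher numbers for weaker inhibition. Compound 1 `CCNS(=O)(=O)c1cccc(-c2ccc(OCC)cc2)c1` gives 200000 nM in this assay. Compound 2 `CCOc1ccc(-c2cccc(C)c2)cc1` gives 70000 nM in this assay. Compound 3 `CCCCOC(=O)c1cccc(-c2ccc(OCC)cc2)c1` gives 100000 nM in this assay; this is the second highest of the three numbers, and its distances to compound 2 and to compound 1 are both within the usual scatter. Within the data shown here, all the measured steps alter the group on an aromatic carbon: a 2.9-fold lower number from compound 1 to compound 2 (0.46 log units; beyond the scatter), a 2.0-fold lower number from compound 1 to compound 3 (0.30 log units; within the scatter) and a 1.4-fold higher number from compound 2 to compound 3 (0.15 log units; within the scatter). Compound 4 `CCOc1ccc(-c2cccc(C(=O)OCCOC)c2)cc1` has not yet been measured. It differs from compound 3 not on the ring but further out in the ester chain: methoxy in place of ethyl on a saturated chain carbon, two bonds along the chain from an oxygen next to a carbonyl group. Among the measured compounds shown here, no measured step touches that chain, so none of them bears directly on this change, and the aromatic substitutions seen so far moved the numbers only modestly. The expected step is therefore no change at the digits printed from compound 3 to compound 4 (within the scatter), none beyond the scatter. Compound 4 is estimated at 100000 nM in this assay, with a range from 30000 nM to 300000 nM.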

Compound 4, half-maximal inhibitory concentration: 70000 nM
Beside the measured number, compound 4's estimate is 1.4-fold (0.15 log units) above it; low and high end bracket the measured number.
By their numbers in this assay, from the lowest: compounds 2, 4, 3 and 1 (each within the scatter of the next, the first and the last beyond it).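

Methoxy in place of ethyl on a saturated chain carbon, two bonds along the chain from an oxygen next to a carbonyl group, gives a 1.4-fold lower number from compound 3 to compound 4 (0.15 log units; within the scatter) in this assay and so stays within the scatter; this is the first look at a change out in the ester chain rather than on the ring. Among these compounds, measured against the methyl group, the (2-methoxyethoxy)carbonyl group gives no change at the digits printed from compound 2 to compound 4 (within the scatter) and measured against the ethylsulfamoyl group it gives a 2.9-fold lower number from compound 1 to compound 4 (0.46 log units; beyond the scatter) as the only new step beyond the scatter. Nothing here accounts for why these numbers fall where they do.

The compounds shown leave open whether an amine or a carboxylic acid at the end of the ester chain would move the number beyond the scatter. Going by these compounds, a longer chain at this position is equally open.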